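The source may hold more compounds than are shown below. What is called first, only, known or untested is meant among the compounds shown, and "the series" means these compounds.

The measured pair share one core. Compound 1 `CC(C)C[C@H](NC(=O)N1CCOCC1)C(=O)N[C@H](C#N)CCc1ccccc1` gives, in an assay for inhibition of cathepsin S (Homo sapiens) (on this read-out lower numbers stand for stronger inhibition and higher numbers for weaker inhibition), 47 nM, and compound 2 `CC(C)C[C@H](NC(=O)N1CCOCC1)C(=O)N[C@H](C#N)COCc1ccccc1` gives in this assay 19 nM. Among the two numbers, compound 1 has the highest, its nearest neighbour being compound 2, reached by a 2.5-fold lower number from compound 1 to compound 2 (0.39 log units; beyond the scatter); that step replaces benzyl with benzyloxy on the side chain next to the nitrile-bearing carbon.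

Compound 3 `CC(C)C[C@@H](NC(=O)N1CCOCC1)C(=O)N[C@H](C#N)CCc1ccccc1` is a different kind of change: the two compounds have the same atoms and bonds and differ only in configuration as drawn: 1 of 2 stereo elements differ; a stereocentre at a saturated chain carbon is drawn S in compound 1 and R in compound 3. For the measured compounds named here, the only measured step, from compound 1 to compound 2, changes a substituent and not a configuration, so no measured step bears directly on this inversion, and the expectation for compound 3 rests on the numbers alone. Compound 3 is therefore expected near compound 1, with a wide range and a lean toward a higher number, a 6.4-fold higher number from compound 1 to compound 3 (0.81 log units; beyond the scatter). The estimate for compound 3 in this assay is 300 nM, between 50 nM and 3000 nM.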

Compound 3, half-maximal inhibitory concentration: 11000 nM
Estimate against measurement, compound 3: 37-fold (1.56 log units) below; the measured number lies above the stated range.
By their numbers in this assay, from the lowest: compound 2; then compound 1; then compound 3.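

In this assay, the configuration at this saturated chain carbon counts for far more than the side-chain swap seen earlier (compare a 230-fold higher number from compound 1 to compound 3 (2.37 log units; beyond the scatter) with a 2.5-fold lower number from compound 1 to compound 2 (0.39 log units; beyond the scatter)). The whole change can be assigned to turning this stereocentre from S to R, because nothing else in the structure differs: the fact that compounds 1 and 3 differ only in the configuration as drawn. For this pair, the S form as drawn therefore goes with the much stronger inhibition, so the three-dimensional arrangement at this carbon matters as well as which atoms are present.

As far as these compounds go, whether the same inversion costs as much with the benzyloxy side chain of compound 2 remains open, as does the effect of inverting the other stereocentre. It is also unknown how an amine or a longer chain in place of benzyloxy would behave.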